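A Single Group Exchanged on an Aromatic Carbon

The compounds below may be only part of what the source reports. "The series", "measured", "known", "first", "only" and "open" are said of these compounds alone.

Among the compounds with values here, compound 1 (`CN(C[C@H]1Cc2c(cccc2N2CCN(C3COC3)CC2)CN1)[C@H]1CCCc2cccnc21`) is the only compound in this small set with a number. In an ADME assay on microsomes from liver (Homo sapiens) for metabolic stability, read by LC-MS, with a stated time of 10 min (on this read-out lower numbers stand for a less stable compound and higher numbers for a more stable compound), compound 1 gives 83.1% and so stands alone on the scale, with no neighbour to rank it against. For compound 2 (`Cc1cnc(CN(C)C[C@H]2Cc3c(cccc3N3CCNCC3)CN2)c(C)c1`) the entry reads "not determined" (no result reported) and offers no comparison.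

Compound 3 (`CN(C[C@H]1Cc2c(cccc2N2CCN3CCC[C@H]3C2)CN1)[C@H]1CCCc2cccnc21`) keeps the core of compound 1 and differs in one place, on an aromatic carbon of a six-membered aromatic ring of carbon only (a group of 9 heavy atoms (7 carbon, 2 nitrogen; one five-membered non-aromatic ring with 1 hetero atom, one six-membered non-aromatic ring with 2 hetero atoms) in place of a group of 10 heavy atoms (7 carbon, 2 nitrogen, 1 oxygen; one four-membered non-aromatic ring with 1 hetero atom, one six-membered non-aromatic ring with 2 hetero atoms), on an aromatic carbon). The 4-(oxetan-3-yl)piperazin-1-yl group leaves, and a group with one five-membered and one six-membered non-aromatic ring enters.

Within the data shown here, no measured pair shows what such an exchange does, so any forecast in this assay rests on compound 1 alone. With compound 1 at 83.1% there is more room downward than upward on this read-out. The expected change is small (a number 7.1 percentage points lower from compound 1 to compound 3 (within the scatter)) and points to a slight fall within the usual scatter. Compound 3 is expected at 76% within an estimated range (55% to 92%).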

Compound 3, percent of the compound remaining: 36.6%
Estimate against measurement, compound 3: 39.4 percentage points above, and the stated range ends above it.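

In this assay, putting the group with one five-membered and one six-membered non-aromatic ring in place of the 4-(oxetan-3-yl)piperazin-1-yl group gives a number 46.5 percentage points lower from compound 1 to compound 3 (beyond the scatter), so the read-out responds strongly to what this aromatic carbon carries. With the core of compound 1 otherwise unchanged, this first measured step shows that the exchange of one group here is enough to move the value beyond the scatter, even though both groups have a six-membered non-aromatic ring with 2 hetero atoms, no hydrogen-bond donors and no net charge. The leaving group has the oxygen and the four-membered ring and the entering group has neither, but nothing measured here connects either difference to the fall.

Within the data shown here, the single step cannot separate the departure of the oxetan-3-yl part from the arrival of the five-membered ring, and compound 2 adds no number that could help. As far as these compounds go, it also remains open where a 4-methylpiperazin-1-yl or a 4-acetylpiperazin-1-yl group on the same aromatic carbon would fall relative to compound 1 and compound 3.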